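Changing the aryl group on the amide nitrogen: compound 4

A few compounds are considered here, and "the series" means these few. Any claim that something is new, unique, unknown or untested is made for them only; others in the source may bear on it.

Three measured compounds share one core and differ only in the group carried by an amide-type nitrogen. Compound 1 `Cc1cc(Br)ccc1NC(=O)COc1ccc2cc(/C=C3/SC(=O)NC3=O)ccc2c1` carries a 4-bromo-2-methylphenyl there, and in an assay on isolated protein for inhibition of histone deacetylase 8 (Homo sapiens), with a stated time of 1 h (on this read-out higher numbers stand for weaker inhibition and lower numbers for stronger inhibition), compound 1 gives 7400 nM. Compound 2 `Cc1cccc2sc(NC(=O)COc3ccc4cc(/C=C5/SC(=O)NC5=O)ccc4c3)nc12` carries a 4-methyl-1,3-benzothiazol-2-yl, and in this assay compound 2 gives 5800 nM; the comparison reads a 1.3-fold lower number from compound 1 to compound 2 (0.11 log units; within the scatter). Compound 3 `COc1ccc(NC(=O)COc2ccc3cc(/C=C4/SC(=O)NC4=O)ccc3c2)cc1` carries a 4-methoxyphenyl. In this assay compound 3 gives > 50000 nM, which is a limit of the assay and not a number (the limit of > 50000 nM in this assay, at which 1 of the 3 values shown sits). Compound 3 therefore stands at the weak end of the set, since an at least 6.7-fold higher number from compound 1 to compound 3 (0.82 log units; beyond the scatter) and an at least 8.6-fold higher number from compound 2 to compound 3 (0.93 log units; beyond the scatter).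

Compound 4 `O=C(COc1ccc2cc(/C=C3/SC(=O)NC3=O)ccc2c1)Nc1cccc(Cl)c1` is not yet measured. From compound 3 to compound 4 the change is 3-chlorophenyl in place of 4-methoxyphenyl on an amide-type nitrogen. Among the measured compounds shown here, the steps that bear on it are the two that led into the 4-methoxyphenyl, both at least modest and both worsening. Compound 4 runs the other way, and its 3-chlorophenyl, like the 4-bromo-2-methylphenyl of compound 1 at 7400 nM, is a phenyl carrying a halogen. A modest improvement is therefore expected, though compound 4 may still sit near the limit. Compound 4 is estimated at 20000 nM, between 6000 nM and 60000 nM, an expected step of an at least 2.5-fold lower number from compound 3 to compound 4 (0.39 log units; beyond the scatter).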

Compound 4, half-maximal inhibitory concentration: > 50000 nM
Compound 4 gave a limit, no number; the forecaster's own chance of this, stated with the estimate: 35%; middle value at least 2.5-fold (0.39 log units) away from the limit.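

Compound 4 ends at a limit of the assay and not at a number in this assay, the same limit that compound 3 reached: the limit of > 50000 nM in this assay, at which 2 of the 4 values shown sit.

The 3-chlorophenyl on the amide-type nitrogen falls short of both groups that gave numbers, with an at least 6.7-fold higher number from compound 1 to compound 4 (0.82 log units; beyond the scatter) and an at least 8.6-fold higher number from compound 2 to compound 4 (0.93 log units; beyond the scatter). A halogen on the phenyl is thus not enough on its own at this position, and with two limits the step from the 4-methoxyphenyl to the 3-chlorophenyl cannot be read.

Still open, going by these compounds, is whether the bromine, the methyl or both set the 4-bromo-2-methylphenyl of compound 1 apart from the 3-chlorophenyl. On these data alone, a 4-bromophenyl and a 2-methylphenyl on the same nitrogen would separate the two, and how a 4-aminophenyl or a 4-carboxyphenyl there would read in this assay also remains unknown.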